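Changing the aryl group on compound 3

A few compounds are considered here, and "the series" means these few. Any claim that something is new, unique, unknown or untested is made for them only; others in the source may bear on it.

compound 1 `Cc1cc(=O)c2c(O)c(CN3CCCC3CO)c(O)c([C@H]3CCN(C)C[C@H]3O)c2o1` gives 15%
compound 2 `CCOC(=O)N1CCN(Cc2c(O)c([C@H]3CCN(C)C[C@H]3O)c3oc(C)cc(=O)c3c2O)CC1` gives 1%
compound 3 `Cc1oc2c([C@H]3CCN(C)C[C@H]3O)c(O)cc(O)c2c(=O)c1C(O)c1ccc(Cl)cc1` gives 41%

In a functional assay on PC-3 cells (Homo sapiens) for inhibition, read by MTT assay, with a stated time of 48 h, tested at 10 uM (a higher number here means more inhibition of growth at the concentration tested, a lower number less inhibition of growth), compound 3 gives 41% as the highest of the three numbers, beyond the scatter from both others. Compound 4 `Cc1oc2c([C@H]3CCN(C)C[C@H]3O)c(O)cc(O)c2c(=O)c1C(O)c1ccccc1Br` carries 2-bromophenyl in place of 4-chlorophenyl on a saturated chain carbon bound to an aromatic carbon and an oxygen on a saturated carbon. For the measured compounds named here, the only measured step (a number 14 percentage points lower from compound 1 to compound 2 (beyond the scatter)) exchanges other groups on another part of the molecule, so it bears only loosely on this change. Going by the values given here, no measured pair exchanges these two groups. In this assay no step beyond the scatter is therefore expected, though with little certainty. The estimate means a number 3 percentage points lower from compound 3 to compound 4 (within the scatter) as the expected step. For compound 4 the estimated value is 38% with an expected range (18% to 58%).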

Compound 4, percent growth inhibition at one concentration: 45%
Estimate against measurement, compound 4: 7 percentage points below, within the range that was stated.
By their numbers in this assay, from the lowest: compound 2; then compound 1; then compounds 3 and 4 (each within the scatter of the next).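

In this assay, putting 2-bromophenyl in place of 4-chlorophenyl on the saturated chain carbon gives a number 4 percentage points higher from compound 3 to compound 4 (within the scatter), the first step shown at this position. The two aryl groups therefore cannot be told apart in this assay, even though both the halogen and its place on the ring differ. Nothing measured here offers an explanation for this result.

The compounds shown leave open which of those two differences matters, if either does. They also leave open whether an unsubstituted phenyl or a pyridine ring would give a similar number at this position.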